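Two changes on one scaffold, combined in compound 4

This account rests on a few compounds, and the source may have more. Where it says the series, first, only, none or still open, it means among the compounds named here.

Measured compounds:
compound 1 `C#CCNC(=O)c1ccc(C(CC)(CC)c2ccc(OCC(=O)C(C)(C)C)c(C)c2)n1CC`: 2200 nM
compound 2 `CCn1c(C(=O)NCC(OC)OC)ccc1C(CC)(CC)c1ccc(OCC(=O)C(C)(C)C)c(C)c1`: 130 nM
compound 3 `C#CCNC(=O)c1ccc(C(CC)(CC)c2ccc(OCC(O)C(C)(C)C)c(C)c2)n1CC`: 240 nM

In an assay on HL-60 cells for agonist activity at vitamin D3 receptor (Homo sapiens), read by microscopy, with a stated time of 96 h (a lower number here means that less compound is needed, a higher number that more compound is needed for the effect), compound 1 gives 2200 nM. One change, (dimethoxymethyl in place of ethynyl on a saturated chain carbon bound to an amide-type nitrogen), leads to compound 2, and the step is a 17-fold lower number from compound 1 to compound 2 (1.23 log units; beyond the scatter). The other change, (1-hydroxy-2,2-dimethylpropyl in place of (tert-butyl)carbonyl on a saturated chain carbon bound to an oxygen on an aromatic ring), leads to compound 3, with the step of a 9.2-fold lower number from compound 1 to compound 3 (0.96 log units; beyond the scatter). Compound 3 and compound 2 lie within the scatter of each other.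

Compound 4 `CCn1c(C(=O)NCC(OC)OC)ccc1C(CC)(CC)c1ccc(OCC(O)C(C)(C)C)c(C)c1` carries both changes. Its core differs from that of compound 1 by 1-hydroxy-2,2-dimethylpropyl in place of (tert-butyl)carbonyl on a saturated chain carbon bound to an oxygen on an aromatic ring, and it differs from compound 3 by dimethoxymethyl in place of ethynyl on a saturated chain carbon bound to an amide-type nitrogen, the same change as from compound 1 to compound 2, made at the same place. Because the earlier step was a 17-fold lower number from compound 1 to compound 2 (1.23 log units; beyond the scatter), compound 4 is expected to show a step of a 9.6-fold lower number from compound 3 to compound 4 (0.98 log units; beyond the scatter) from compound 3, somewhat smaller, since the two gains need not add fully. Compound 4 is therefore estimated at 25 nM, between 8 nM and 80 nM.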

Compound 4, half-maximal effective concentration: 150 nM
For compound 4 the middle estimate is 6.0-fold (0.78 log units) below the measured one; measured number above the stated range.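

On the core carrying 1-hydroxy-2,2-dimethylpropyl in this assay, dimethoxymethyl in place of ethynyl gives only a 1.6-fold lower number from compound 3 to compound 4 (0.20 log units; within the scatter), so this change does not carry over at its earlier size: the same change on two cores in this assay, a 17-fold lower number (1.23 log units; beyond the scatter) from compound 1 to compound 2 and a 1.6-fold lower number (0.20 log units; within the scatter) from compound 3 to compound 4, 11-fold (1.02 log units) apart, beyond the scatter of two such steps. Likewise, 1-hydroxy-2,2-dimethylpropyl in place of (tert-butyl)carbonyl gives a 1.2-fold higher number from compound 2 to compound 4 (0.06 log units; within the scatter) on the core carrying dimethoxymethyl, and this step also differs from its earlier counterpart: the same change on two cores in this assay, a 9.2-fold lower number (0.96 log units; beyond the scatter) from compound 1 to compound 3 and a 1.2-fold higher number (0.06 log units; within the scatter) from compound 2 to compound 4, 11-fold (1.02 log units) apart, beyond the scatter of two such steps. The two gains therefore do not add in this set, but a single pair of changes on these cores does not show why, or whether other pairs of changes in the series would behave alike. From the compounds shown here alone, it remains open whether an amine, a carboxylic acid or a longer chain in place of dimethoxymethyl would give steps that depend on the core in the same way.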